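This account rests on a few compounds, and the source may have more. Where it says the series, first, only, none or still open, it means among the compounds named here.

In an ADME assay on S9 fraction from liver (Rattus norvegicus) for metabolic stability, read by LC-MS, using NADPH, with a stated time of 30 min (on this read-out lower numbers stand for a less stable compound and higher numbers for a more stable compound), compound 1 `CCCCCCCCc1ccc(OCC(=O)Cn2nnc(-c3cccc(Cl)c3)n2)cc1` gives 69%. Compound 2 `CCCCCCCCc1ccc(OCC(=O)Cn2nnc(Cc3ccccc3)n2)cc1` has only a limit in this read-out, < 5%, so no exact value is available for it. Compound 3 `CCCCCCCCc1ccc(OCC(=O)Cn2nnc(-c3ccc(C(=O)O)cc3)n2)cc1` differs from compound 2 by one change, 4-carboxyphenyl in place of benzyl on an aromatic carbon. Among the measured compounds shown here, one measured step bears on this, the large drop a number at least 64 percentage points lower from compound 1 to compound 2 (beyond the scatter), which lies beyond the scatter and came with benzyl in place of 3-chlorophenyl on the same aromatic carbon. Compound 3 also loses that benzyl group, but it has 4-carboxyphenyl rather than the 3-chlorophenyl of compound 1, and no measurement covers that difference. A large upward step is therefore expected in this assay, estimated as a number at least 55 percentage points higher from compound 2 to compound 3 (beyond the scatter). For compound 3 the estimated value is 60%, with an expected range of 30% to 88%.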

Compound 3, percent of the compound remaining: < 5%
Compound 3: no number, only a limit (the forecaster's own chance of this, stated with the estimate: 7%); middle value at least 55 percentage points from the limit.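

In this assay compound 3 gives < 5%, which is a limit of the assay and not a number. At this position, 4-carboxyphenyl in place of 3-chlorophenyl brings a number at least 64 percentage points lower from compound 1 to compound 3 (beyond the scatter), so a six-membered aromatic ring bound directly to this carbon does not by itself keep the value seen for compound 1, and the loss is not confined to benzyl. Compound 2 and compound 3 both carry limits, so the step between them cannot be read, and the two share the same limit: the limit of < 5% in this assay, at which 2 of the 3 values shown sit.

The change from compound 1 to compound 3 alters both the group on the ring and where it sits, and the compounds shown do not separate these two. From the compounds shown here alone, how 4-chlorophenyl, 3-carboxyphenyl or unsubstituted phenyl would behave at this carbon stays open.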